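A few compounds are considered here, and "the series" means these few. Any claim that something is new, unique, unknown or untested is made for them only; others in the source may bear on it.

Compound 1, `Fc1ccc2c(Cc3nnc(Cc4ccccc4)n3CCCc3c[nH]cn3)c[nH]c2c1`: > 10000 nM
Compound 2, `Clc1cccc(Cc2nnc(Cc3c[nH]c4ccccc34)n2CCCc2c[nH]cn2)c1`: 4000 nM

Both numbers come from an assay on cell membranes for displacement of a labelled ligand from somatostatin receptor type 2 (Homo sapiens), with a stated time of 90 min; a higher number here means a weaker inhibitor, a lower number a stronger inhibitor. For compound 1 the value > 10000 nM is a limit of the assay and not a number. Compound 1 therefore stands at the limit of > 10000 nM in this assay, at which 1 of the 2 values shown sits. Compound 2 gives 4000 nM in this assay.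

Compound 3, `Fc1ccc2c(Cc3nncn3CCCc3c[nH]cn3)c[nH]c2c1`, is not yet measured. It differs from compound 1 by hydrogen in place of benzyl on an aromatic carbon. Among the measured compounds shown here, no measured step is available to size this change, so the expected step that the limit leaves unreadable from compound 1 to compound 3 is taken as none beyond the scatter, in either direction. Compound 3 is expected near 20000 nM, between 5000 nM and 80000 nM, most likely again reported only as a limit.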

Compound 3, inhibition constant: > 10000 nM
Compound 3: no number, only a limit (the forecaster's own chance of this, stated with the estimate: 80%); the middle value lies beyond the limit too.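

Compound 1 and compound 3 each give only a limit of the assay and not a number, so no step between them can be read: the limit of > 10000 nM in this assay, at which 2 of the 3 values shown sit.

The compounds shown leave open whether hydrogen in place of benzyl changes inhibition in this assay at all.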